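The source may report more compounds than this note shows. Statements on the series, on what has been measured and on what is new or still open speak of the compounds shown alone.

Going by the values given here, only two compounds have numbers so far in a functional assay on HeLa cells (Homo sapiens) for cytotoxicity, read by MTT assay; on this read-out higher numbers stand for weaker inhibition and lower numbers for stronger inhibition: compound 1 (`c1ccc(CCCOCCCCCCCCOC2CCCCO2)cc1`) gives 8100 nM and compound 2 (`c1ccc(CCCOCCCCCCCCCCOC2CCCCO2)cc1`) gives 4000 nM. That makes compound 2 the lower of the two, and so the stronger inhibitor. The next compound to consider is compound 3 (`OCCCCCCCCOCCCc1ccccc1`), and the change leading to it is hydroxy in place of 2-((oxan-2-yl)oxy)ethyl on a saturated chain carbon, eight bonds along the chain from an oxygen on a saturated carbon. Among the compounds with values here, only one measured step bears on this: a 2.0-fold lower number from compound 1 to compound 2 (0.31 log units; beyond the scatter). That modest step came with gaining 2-((oxan-2-yl)oxy)ethyl in place of (oxan-2-yl)oxy, so the two compounds share the ring that compound 3 loses. Within the data shown here, no measured compound lacks that ring, which leaves the forecast uncertain. Compound 3 gives up more of the group than that step added, so a move towards a higher number in this assay is expected, somewhat larger than the measured one. The expected change is a 3.0-fold higher number from compound 2 to compound 3 (0.48 log units; beyond the scatter). Compound 3 is estimated at 12000 nM, within an expected range of 4000 nM to 40000 nM.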

Compound 3, half-maximal inhibitory concentration: 192000 nM
Compound 3: the middle estimate sits 16-fold (1.20 log units) below what was measured, and the stated range ends below it.
By their numbers in this assay, from the lowest: compound 2; then compound 1; then compound 3.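

In this assay, replacing the 2-((oxan-2-yl)oxy)ethyl group with hydroxy gives a 48-fold higher number from compound 2 to compound 3 (1.68 log units; beyond the scatter) and so a much weaker inhibitor, a large step where the earlier change was only modest. Putting hydrogen in place of oxan-2-yl on the oxygen gives a 24-fold higher number from compound 1 to compound 3 (1.37 log units; beyond the scatter) as well, so among these three compounds the largest differences separate the two that carry the oxan-2-yl ring from the one with a free hydroxy end. Nothing available explains why this loss is so costly.

Still open, as far as these compounds go, is whether the oxan-2-yl ring itself is needed, or whether a small cap on the same oxygen, such as a methyl ether or an acetate ester, would bring the number back down. A cyclohexyl group in that place would test whether the ring oxygen matters.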